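A few compounds are considered here, and "the series" means these few. Any claim that something is new, unique, unknown or untested is made for them only; others in the source may bear on it.

Among the compounds with values here, compound 1 `CCOc1cc(=O)oc2cc(OCc3cccc(Cl)c3)ccc12` gives 115 nM in an assay on isolated protein (strain Sprague-Dawley) for inhibition of Amine oxidase [flavin-containing] B (Rattus norvegicus), read by spectrophotometry, with a stated time of 5 min (on this read-out lower numbers stand for stronger inhibition and higher numbers for weaker inhibition), which is the higher of the two numbers measured so far; compound 2 `CC(=O)c1cc(=O)oc2cc(OCc3cccc(Cl)c3)ccc12` gives 39.8 nM in this assay. Compound 3 `CCOC(=O)c1cc(=O)oc2cc(OCc3cccc(Cl)c3)ccc12` differs from compound 1 by ethoxycarbonyl in place of ethoxy on an aromatic carbon. Within the data shown here, the one measured step that bears on this change is a 2.9-fold lower number from compound 1 to compound 2 (0.46 log units; beyond the scatter), a modest step toward a lower number. The chemist therefore expects a step of similar direction and size, namely a 2.3-fold lower number from compound 1 to compound 3 (0.36 log units; beyond the scatter). In this assay compound 3 is accordingly estimated at 50 nM, with a likely range from 20 nM to 130 nM.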

Compound 3, half-maximal inhibitory concentration: 417 nM
Compound 3: middle estimate off by 8.3-fold (0.92 log units), on the low side; the measured number lies above the stated range.
By their numbers in this assay, from the lowest: compound 2; then compound 1; then compound 3.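

At this position, a carbonyl attached to the ring does not by itself bring the lower number seen with acetyl: in this assay, ethoxycarbonyl in place of ethoxy gives a 3.6-fold higher number from compound 1 to compound 3 (0.56 log units; beyond the scatter), opposite in direction to the acetyl change. Ethoxy in place of methyl on the carbonyl carbon gives a 10-fold higher number from compound 2 to compound 3 (1.02 log units; beyond the scatter), so what is attached to that carbon matters here, not the carbonyl alone. Nothing measured here explains this reversal. From the compounds shown here alone, how a longer chain on the ester oxygen, an amide or a carboxylic acid would read at this position remains open.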